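From Ethyl to Tert-Butyl on the Shared Core

The source may hold more compounds than are shown below. What is called first, only, known or untested is meant among the compounds shown, and "the series" means these compounds.

In a functional assay on HeLa cells (Homo sapiens) for inhibition (a lower number here means a stronger inhibitor, a higher number a weaker inhibitor), compound 1 `Cc1ccc(C(=O)CC(SCC(=O)O)C(=O)O)cc1C` gives 3810 nM while compound 2 `Cc1ccc(C(=O)CC(SCC(=O)O)C(=O)O)c(C)c1` gives 3830 nM and compound 3 `CCc1ccc(C(=O)CC(SCC(=O)O)C(=O)O)cc1` gives 4790 nM on the same read-out. Compound 3 therefore stands within the scatter of both other compounds, and the three cannot be ranked. Compound 4 `CC(C)(C)c1ccc(C(=O)CC(SCC(=O)O)C(=O)O)cc1` carries tert-butyl in place of the ethyl of compound 3 on an aromatic carbon, para to a large group tert-butyl in place of ethyl on an aromatic carbon in this comparison. For the measured compounds named here, no measured pair isolates this change, so the expectation rests only on the three close values. A step of a 1.1-fold lower number from compound 3 to compound 4 (0.06 log units; within the scatter) is expected in this assay and should stay within the scatter. Compound 4 is estimated at 4200 nM with 2000 nM to 9000 nM as the expected range.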

Compound 4, half-maximal inhibitory concentration: 1390 nM
Compound 4: the middle estimate sits 3.0-fold (0.48 log units) above what was measured; measured number below the stated range.
By their numbers in this assay, from the lowest: compound 4; then compounds 1, 2 and 3 (each within the scatter of the next).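

Tert-butyl in place of ethyl on an aromatic carbon, para to a large group, gives a 3.4-fold lower number from compound 3 to compound 4 (0.54 log units; beyond the scatter) in this assay, the first difference among these compounds that lies beyond the scatter. This position therefore does respond to the group it carries, which the three close earlier values could not show. Nothing available bears on why this step occurs. On these data alone, it remains open how isopropyl, a longer chain such as n-butyl, or an amine would read at this position, and a single step cannot show whether the number keeps falling with still larger alkyl groups.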